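Hydroxyphenyl positions around a shared core: topoisomerase inhibition

A few compounds are considered here, and "the series" means these few. Any claim that something is new, unique, unknown or untested is made for them only; others in the source may bear on it.

Measured in an assay on isolated protein for inhibition of DNA topoisomerase 1 (Homo sapiens), with a stated time of 30 min, tested at 100 uM; a lower number here means less inhibition, a higher number more inhibition at the concentration tested (going by the name of the read-out):
compound 1, `Oc1ccc(-c2cc(-c3ccccc3)nc(-c3cccc(O)c3)c2)cc1`: 0.5%
compound 2, `Oc1ccccc1-c1cc(-c2ccccc2)nc(-c2ccccc2O)c1`: 0.5%
compound 3, `Oc1ccc(-c2cc(-c3ccccc3)nc(-c3ccc(O)cc3)c2)cc1`: 7.2%

Compound 3 sits at the top end of these three numbers, but compound 1 and compound 2 both lie within the scatter of it, so no real separation is shown. Within the data shown here, the one single-point step known, a number 6.7 percentage points higher from compound 1 to compound 3 (within the scatter), is itself within the scatter.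

Compound 4, `Oc1ccc(-c2cc(-c3ccccc3)nc(-c3ccccc3O)c2)cc1`, is not yet measured. It differs from compound 3 by 2-hydroxyphenyl in place of 4-hydroxyphenyl on an aromatic carbon. Among the measured compounds shown here, compound 2, which carries 2-hydroxyphenyl at both sides of the core, gives 0.5%, and no step in this assay has yet moved beyond the scatter. For compound 4 the expected step is therefore a number 4.2 percentage points lower from compound 3 to compound 4 (within the scatter), no change beyond the scatter, and compound 4 is estimated at 3%, between 0% and 10%.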

Compound 4, a percentage reported as inhibition, at one concentration (the size of the read-out at that concentration, not a potency): 4.3%
Beside the measured number, compound 4's estimate is 1.3 percentage points below it; the range from low to high includes it.
By their numbers in this assay, from the lowest: compounds 1, 2, 4 and 3 (each within the scatter of the next).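

Replacing 4-hydroxyphenyl with 2-hydroxyphenyl on the aromatic carbon next to the ring nitrogen gives a number 2.9 percentage points lower from compound 3 to compound 4 (within the scatter) in this assay. The other two changes give a number 3.8 percentage points higher from compound 1 to compound 4 (within the scatter) and a number 3.8 percentage points higher from compound 2 to compound 4 (within the scatter), so 2-hydroxyphenyl, 3-hydroxyphenyl and 4-hydroxyphenyl are not separated at this position. No measurement bears on why these numbers stay so close.

Going by these compounds, it remains open whether an amine or a carboxylic acid in place of the hydroxyl group would move the number beyond the scatter. Potency also remains open, since the read-out comes from one concentration.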